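The source may hold more compounds than are shown below. What is called first, only, known or untested is meant among the compounds shown, and "the series" means these compounds.

Working notes on the thiosemicarbazone series. Among the compounds with values here, compound 2, `Fc1ccc(Oc2ccc(/C=N/NC(=S)Nc3ccc(Br)cc3)cc2)cc1`, sits second highest of the three numbers measured so far: in a physicochemical assay for lipophilicity, in phosphate buffer, measured as octanol-water partition, with a stated time of 24 h (a higher number here means a more lipophilic compound, a lower number a more polar compound), compound 2 gives 5.82. Compound 1, `Fc1ccc(Oc2ccc(/C=N/NC(=S)Nc3ccc(Cl)cc3)cc2)cc1`, gives 5.84 in this assay, and a number 0.02 log units lower from compound 1 to compound 2 (within the scatter). Compound 3, `Fc1ccc(Oc2ccc(/C=N/NC(=S)Nc3ccccc3)cc2)cc1`, gives 5.09 in this assay; a number 0.73 log units lower from compound 2 to compound 3 (beyond the scatter), and a number 0.75 log units lower from compound 1 to compound 3 (beyond the scatter). Compound 4, `O=[N+]([O-])c1ccc(Oc2ccc(/C=N/NC(=S)Nc3ccc(Br)cc3)cc2)cc1`, is not yet measured. It differs from compound 2 by nitro in place of fluoro on an aromatic carbon, that is 4-fluorophenyl to 4-nitrophenyl. Within the data shown here, none of the measured steps touches this ring; all three concern the halogen on the other ring, so no measured step bears directly on the change. A modest fall in this assay is nonetheless expected, a number 0.42 log units lower from compound 2 to compound 4 (beyond the scatter). Compound 4 is estimated at 5.4, within a range of 4.9 to 5.9.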

Compound 4, partition coefficient: 5.68
Compound 4: the middle estimate sits 0.28 log units below what was measured; the measured number falls inside the stated range.
By their numbers in this assay, from the lowest: compound 3; then compounds 4, 2 and 1 (each within the scatter of the next).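

Within the data shown here, this is the first reading at the 4-fluorophenyl end of the series. In this assay the step reads a number 0.14 log units lower from compound 2 to compound 4 (within the scatter), so nitro in place of fluoro, with more heavy atoms and hydrogen-bond acceptors entering, leaves the number within the scatter, unlike the step on the other ring, a number 0.73 log units lower from compound 2 to compound 3 (beyond the scatter). Nothing available accounts for this result.

As far as these compounds go, whether an amine or a carboxylic acid on this aromatic carbon would also stay within the scatter of compound 2 remains open. So does whether nitro in place of fluoro reads the same with chloro or hydrogen on the other ring.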